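Fluoro to bromo: one swap on the phenyl ring

The compounds below may be only part of what the source reports. "The series", "measured", "known", "first", "only" and "open" are said of these compounds alone.

Compound 1 (`Clc1ccc(-c2ccnc3c2c(-c2ccccc2)nn3-c2ccccc2)cc1`): 61100 nM
Compound 2 (`Fc1ccc(-c2ccnc3c2c(-c2ccccc2)nn3-c2ccccc2)cc1`): 1570 nM

For the measured compounds named here, in a functional assay on HepG2 cells (Homo sapiens) for inhibition, read by MTT assay, with a stated time of 48 h (on this read-out lower numbers stand for stronger inhibition and higher numbers for weaker inhibition), compound 2 gives 1570 nM and holds the lower of the two numbers so far. Compound 3 (`Brc1ccc(-c2ccnc3c2c(-c2ccccc2)nn3-c2ccccc2)cc1`) differs from it in one place (bromo in place of fluoro on an aromatic carbon), with bromo in place of fluoro on an aromatic carbon. Going by the values given here, only one measured step bears on this swap: a 39-fold lower number from compound 1 to compound 2 (1.59 log units; beyond the scatter) with fluoro in place of chloro, a large change. Among the compounds with values here, no measured compound yet carries bromo, so that step guides the direction better than the size. In this assay the expected step is a 13-fold higher number from compound 2 to compound 3 (1.11 log units; beyond the scatter) and it points to a higher number. For compound 3 the estimate is 20000 nM (expected range 4000 nM to 90000 nM).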

Compound 3, half-maximal inhibitory concentration: 49900 nM
Beside the measured number, compound 3's estimate is 2.5-fold (0.40 log units) below it; the range from low to high includes it.
By their numbers in this assay, from the lowest: compound 2; then compounds 3 and 1 (each within the scatter of the next).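

In this assay fluoro is the halogen that stands apart at this position: the swap to bromo is large (a 32-fold higher number from compound 2 to compound 3 (1.50 log units; beyond the scatter)), whereas bromo and chloro cannot be told apart (a 1.2-fold lower number from compound 1 to compound 3 (0.09 log units; within the scatter)). The earlier pair showed only that fluoro and chloro differ; this result shows that a second halogen lands with chloro, leaving compound 2 alone. Nothing available explains this difference. Still open, as far as these compounds go, is what an amine, a methoxy group or a plain hydrogen would give at this position, and whether any would go lower than compound 2.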